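Removing the aminobutyl side chain from compound 2

The source may hold more compounds than are shown below. What is called first, only, known or untested is meant among the compounds shown, and "the series" means these compounds.

compound 1, `O=C(CN(c1ncnc2c1ncn2C1CCCCO1)C1CC1)N[C@@H](CO)C(=O)OCc1ccccc1`: 18.3%
compound 2, `NCCCC[C@H](NC(=O)CN(c1nc(Cl)nc2[nH]cnc12)C1CC1)C(=O)OCc1ccccc1`: 9.88%

In a functional assay on the whole organism (Tail, strain ICR) with Mus musculus as the target, in the tail flick test, with a stated time of 150 min, at a dose of 25 umol/kg by the oral route (a lower number here means a weaker effect, a higher number a stronger effect of the compound at the dose given), compound 2 gives 9.88% and stands with compound 1, whose 18.3% lies within the scatter of it, so no order between the two can be read. Compound 3, `C[C@H](NC(=O)CN(c1nc(Cl)nc2[nH]cnc12)C1CC1)C(=O)OCc1ccccc1`, is not yet measured. It differs from compound 2 by hydrogen in place of 3-aminopropyl on a saturated chain carbon, two bonds along the chain from an amide-type nitrogen and a carbonyl carbon. Among the measured compounds shown here, no measured pair shows this change, so its effect is unknown from these data. Because compound 2 gives 9.88%, a small number, the step is expected to be small, a number 2.1 percentage points higher from compound 2 to compound 3 (within the scatter), within the scatter in either direction. Compound 3 is estimated at 12%, ranging from 2% to 26%.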

Compound 3, a percentage reported as activity, at one dose (the size of the read-out at that dose, not a potency): 23%
The estimate for compound 3 lay 11 percentage points below the measured number; low and high end bracket the measured number.
By their numbers in this assay, from the lowest: compounds 2, 1 and 3 (each within the scatter of the next, the first and the last beyond it).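

In this assay, the change from 3-aminopropyl to hydrogen at this saturated chain carbon gives a number 13.1 percentage points higher from compound 2 to compound 3 (beyond the scatter), the first step measured at this position. With the same difference read as 4-aminobutyl to methyl, the amine-bearing chain proves unnecessary for the effect at this dose, and its removal brings a modest gain. Nothing available bears on the reason for this step.

The amine and the chain length change together here, so their shares stay apart only in a comparison with a plain butyl chain. From the compounds shown here alone, whether a carboxylic acid at the chain end would behave like the amine also remains open.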